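Thioether side-chain variation on the shared core

The source may report more compounds than this note shows. Statements on the series, on what has been measured and on what is new or still open speak of the compounds shown alone.

Going by the values given here, compound 1 `Cc1cc(N2CC[C@@H](C)[C@@H](N(C)c3ncnc4[nH]ccc34)C2)n2nc(SCC3CCCCC3)nc2n1` carries a (cyclohexylmethyl)sulfanyl group on the shared core; in a functional assay on MGC-803 cells (Homo sapiens) for inhibition, read by MTT assay, with a stated time of 72 h (on this read-out lower numbers stand for stronger inhibition and higher numbers for weaker inhibition), compound 1 gives 9170 nM, the second highest of the three numbers measured so far. Compound 2 `Cc1cc(N2CC[C@@H](C)[C@@H](N(C)c3ncnc4[nH]ccc34)C2)n2nc(SCc3cc(Cl)ccc3Cl)nc2n1` gives 9850 nM, and compound 3 `Cc1cc(N2CC[C@@H](C)[C@@H](N(C)c3ncnc4[nH]ccc34)C2)n2nc(SCCc3ccccc3)nc2n1` gives 6190 nM. The steps among them are small: a 1.1-fold higher number from compound 1 to compound 2 (0.03 log units; within the scatter), a 1.5-fold lower number from compound 1 to compound 3 (0.17 log units; within the scatter) and a 1.6-fold lower number from compound 2 to compound 3 (0.20 log units; within the scatter), each within the scatter, so swapping the group on the saturated chain carbon bound to the sulfur has so far left this assay unmoved.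

Compound 4 `C#CSc1nc2nc(C)cc(N3CC[C@@H](C)[C@@H](N(C)c4ncnc5[nH]ccc45)C3)n2n1` is not yet measured. Relative to compound 1 the change is ethynyl in place of cyclohexylmethyl on a sulfur. This is a different kind of alteration from the three measured steps, which all kept a saturated chain carbon on the sulfur and varied only the ring beyond it; none of them bears directly on the removal of that carbon and its ring in favour of ethynyl. What the measured steps do show is that the thioether side chain tolerates wide variation without a step beyond the scatter, and on that basis no step beyond the scatter is expected for compound 4 either, while the uncertainty is wider than for the measured swaps. The expected step is a 1.0-fold lower number from compound 1 to compound 4 (0.01 log units; within the scatter), giving an estimate for compound 4 of 9000 nM with a range from 3000 nM to 27000 nM.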

Compound 4, half-maximal inhibitory concentration: 18100 nM
For compound 4 the middle estimate is 2.0-fold (0.30 log units) below the measured one, within the range that was stated.
By their numbers in this assay, from the lowest: compounds 3, 1, 2 and 4 (each within the scatter of the next, the first and the last beyond it).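

Working notes on the sulfur substituent: in this assay, the exchange for ethynyl gives the first step at this position that lies beyond the scatter (a 2.9-fold higher number from compound 3 to compound 4 (0.47 log units; beyond the scatter)), a modest one measured against phenethyl. The same exchange stays within the scatter against the other two side chains (a 2.0-fold higher number from compound 1 to compound 4 (0.30 log units; within the scatter); a 1.8-fold higher number from compound 2 to compound 4 (0.26 log units; within the scatter)), so ethynyl separates from phenethyl only, and not from cyclohexylmethyl or 2,5-dichlorobenzyl. The position is therefore not wholly indifferent to what sits on the sulfur, but this rests on a single pair, and no measurement at hand accounts for that step.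

Ethynyl differs from cyclohexylmethyl both in having no ring and in carrying a triple bond, and these two changes cannot be told apart here; a plain ethyl group on the sulfur would be needed to separate them. Also open, on these data alone, is how this assay responds to a side chain ending in an amine or a carboxylic acid, or to a phenyl ring on a longer chain than that of phenethyl.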